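This account rests on a few compounds, and the source may have more. Where it says the series, first, only, none or still open, it means among the compounds named here.

Compound 1, with the structure `COc1cc2c(Oc3ccc(NC(=O)N/N=C/c4ccc(F)cc4Cl)cc3F)ccnc2cc1OCCCN1CCCCC1`, belongs to a small set of close relatives. In an ADME assay on PBL cells (Homo sapiens) for cytotoxicity, read by MTT assay, with a stated time of 72 h (on this read-out higher numbers stand for weaker inhibition and lower numbers for stronger inhibition), compound 1 has no single number, since its entry reads "not determined" (no result reported). Compound 2, with the structure `COc1cc2c(Oc3ccc(NC(=O)N/N=C/c4cc5ccccc5[nH]4)cc3F)ccnc2cc1OCCCN1CCCCC1`, is in the same position: in this assay compound 2 also stands at "not determined" (no result reported). For the measured compounds named here, the one relative with a number is compound 3, the structure `COc1cc2c(Oc3ccc(NC(=O)N/N=C/c4cccs4)cc3F)ccnc2cc1OCCCN1CCCCC1`, and in this assay compound 3 gives 68700 nM, a weak effect.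

Compound 4, the structure `COc1cc2c(Oc3ccc(NC(=O)N/N=C/c4ccc(F)cc4Cl)cc3F)ccnc2cc1OCCCN1CCC(C)CC1`, differs from compound 1 in a single spot: methyl in place of hydrogen on a saturated ring carbon, three ring bonds from the ring nitrogen. Going by the values given here, no pair of measured compounds that differ in this way has a known step, so nothing shows which way a change of this kind moves the read-out. The expectation is a step of no clear direction and no size beyond the usual scatter, resting on the weak effect of compound 3 at 68700 nM. On that basis compound 4 is expected to give about 50000 nM, within a range from 15000 nM to 150000 nM.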

Compound 4, half-maximal inhibitory concentration: 79500 nM
Estimate against measurement, compound 4: 1.6-fold (0.20 log units) below, within the range that was stated.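

In this assay, for the compounds shown here, compound 1 has no single number, and no step from it to compound 4 can be read. The compounds shown leave open whether 4-methylpiperidin-1-yl in place of piperidin-1-yl moves this read-out at all. No other data here bear on the result.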